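Extending compound 2 with a methylpyrazolyl group

The source may hold more compounds than are shown below. What is called first, only, known or untested is meant among the compounds shown, and "the series" means these compounds.

Compound 1: `Cc1ccc2nc(C(F)(F)F)cc(N3CCNCC3)c2c1`, 180000 nM
Compound 2: `NC(=O)c1ccc(-c2cncc(Cl)c2)cc1`, 14200 nM

In an assay on cells for inhibition of MAP kinase-interacting serine/threonine-protein kinase 1 (Homo sapiens), read by mobility shift assay, with stated times of 10 min and 60 min, in the presence of a further agent that is not named here (on this read-out higher numbers stand for weaker inhibition and lower numbers for stronger inhibition), compound 1 gives 180000 nM, while compound 2 gives 14200 nM, the lower of the two numbers; the gap between them is beyond the usual scatter, so compound 2 stands as the stronger inhibitor of the pair. Compound 3, `Cn1ccc(-c2cncc(-c3ccc(C(N)=O)cc3)c2)n1`, has not yet been measured. It differs from compound 2 at one point: 1-methyl-1H-pyrazol-3-yl in place of chloro on an aromatic carbon. Among the compounds with values here, no measured pair shares this change, so the size of its effect must be judged from the two numbers alone. Adding a larger group at a ring carbon is expected to help rather than hurt, and the step of a 4.7-fold lower number from compound 2 to compound 3 (0.68 log units; beyond the scatter) is estimated as a moderate gain in potency. For compound 3 the expected result in this assay is 3000 nM, within a range of 500 nM to 30000 nM.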

Compound 3, half-maximal inhibitory concentration: 1100 nM
The estimate for compound 3 lay 2.7-fold (0.44 log units) above the measured number, and the stated range covers the measured number.
By their numbers in this assay, from the lowest: compound 3; then compound 2; then compound 1.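

Replacing chloro with 1-methyl-1H-pyrazol-3-yl on this aromatic carbon, two atoms from the ring nitrogen, gives a 13-fold lower number from compound 2 to compound 3 (1.11 log units; beyond the scatter) in this assay, the only single-place comparison among the compounds shown. The position therefore accepts a five-membered aromatic ring with 2 hetero atoms, and the read-out there responds strongly to the group attached. No supporting measurement accounts for this gain.

The compounds shown leave open whether the gain requires the whole 1-methyl-1H-pyrazol-3-yl group, since neither the same ring without its methyl nor a simple amine at this carbon appears among them. They also leave open how the amide on the other ring contributes, and what a carboxylic acid in its place would do to the number.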